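The compounds below may be only part of what the source reports. "The series", "measured", "known", "first", "only" and "open" are said of these compounds alone.

Compound 1 `NC(=O)c1ccc(-c2cnc(C(O)CCc3ccc(-c4ccccc4)cc3)o2)nc1` in an assay for inhibition of Fatty-acid amide hydrolase 1 (Rattus norvegicus) (on this read-out higher numbers stand for weaker inhibition and lower numbers for stronger inhibition), gives > 1000 nM, which is a limit of the assay and not a number.
Compound 2 `COC(=O)c1ccc(-c2cnc(C(O)CCc3ccc(-c4ccccc4)cc3)o2)nc1` in this assay gives 1100 nM.
Compound 3 `O=C(O)c1cccc(-c2cnc(C(O)CCc3ccc(-c4ccccc4)cc3)o2)n1` in this assay gives 1100 nM.

Compound 3 stands level with compound 2 at the digits shown: the step of no change at the digits printed from compound 2 to compound 3 (within the scatter) lies within the scatter. Compound 1 sits at the limit of > 1000 nM in this assay, at which 1 of the 3 values shown sits, so the steps a step that the limit leaves unreadable from compound 1 to compound 2 and a step that the limit leaves unreadable from compound 1 to compound 3 cannot be read for size. All three measured compounds keep the hydroxy on the chain and differ only in the group carried on the aromatic ring of the shared core.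

Compound 4 `O=C(O)c1cccc(-c2cnc(CCCc3ccc(-c4ccccc4)cc3)o2)n1` differs from compound 3 by hydrogen in place of hydroxy on a saturated chain carbon bound to an aromatic carbon and a saturated chain carbon. Among the compounds with values here, none of the measured steps touches this position; each concerns the substituent on the aromatic ring, so no measured step bears directly on the change from compound 3 to compound 4. With no comparison at this position to lean on, a step of a 1.1-fold higher number from compound 3 to compound 4 (0.04 log units; within the scatter) in this assay is expected, one not beyond the scatter in either direction. Compound 4 is therefore estimated at 1200 nM, with a range from 400 nM to 4000 nM.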

Compound 4, inhibition constant: 10000 nM
Estimate against measurement, compound 4: 8.3-fold (0.92 log units) below; the whole stated range lies below it.
By their numbers in this assay, from the lowest: compounds 2 and 3 (each within the scatter of the next); then compound 4.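

Hydrogen in place of hydroxy on a saturated chain carbon bound to an aromatic carbon and a saturated chain carbon gives, in this assay, a 9.1-fold higher number from compound 3 to compound 4 (0.96 log units; beyond the scatter), whereas the only readable step among the earlier compounds, a change in the group on the aromatic ring, was no change at the digits printed from compound 2 to compound 3 (within the scatter). Within the data shown here, this is the first sign that the chain position is not neutral: on this read-out, the pair shows weaker inhibition once the hydroxy has gone, although this rests on a single pair of compounds. Nothing given here measures a property that would explain the size of this step.

The compounds shown leave open whether the hydroxy itself matters or whether another group on that carbon, such as a carbonyl, a methoxy, an amine or a fluorine, would serve as well. They also leave open whether removing the hydroxy costs as much when the aromatic ring carries the methyl ester of compound 2 or the amide of compound 1 in place of the carboxylic acid of compound 3.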